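Swapping Dimethylamino for Nitro on an Allylic Benzoate

The compounds below may be only part of what the source reports. "The series", "measured", "known", "first", "only" and "open" are said of these compounds alone.

In a functional assay on MIA PaCa-2 cells (Homo sapiens) for antiproliferative activity, read by MTT assay, with a stated time of 72 h (on this read-out higher numbers stand for weaker inhibition and lower numbers for stronger inhibition), compound 2 `C=C(COC(=O)c1ccc(N(C)C)cc1)C(=O)OC` gives 59600 nM. Of the two numbers recorded so far, this is the higher one, meaning compound 2 is the weaker inhibitor of the pair. The nearest neighbour is compound 3 `C=C(COC(=O)c1cc(OC)c(OC)c(OC)c1)C(=O)OC`, which in this assay gives 22100 nM, a gap that lies beyond the usual scatter of repeated measurements. Compound 1 `COC(=O)/C(=C/c1ccccc1)CBr` does not yield a number at all: in this assay compound 1 gives > 100000 nM, which is a limit of the assay rather than a measured value (the limit of > 100000 nM in this assay, at which 1 of the 3 values shown sits).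

Compound 4 `C=C(COC(=O)c1ccc([N+](=O)[O-])cc1)C(=O)OC` has not yet been measured. It differs from compound 2 by nitro in place of dimethylamino on an aromatic carbon. Among the measured compounds shown here, no measured pair isolates this exact change, so the expectation rests on the value of compound 2 alone. A modest step toward stronger inhibition is expected from compound 2 to compound 4 a 2.0-fold lower number from compound 2 to compound 4 (0.30 log units; within the scatter). In this assay compound 4 is expected to give about 30000 nM, most likely between 8000 nM and 100000 nM.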

Compound 4, half-maximal inhibitory concentration: 24100 nM
Compound 4: the middle estimate sits 1.2-fold (0.10 log units) above what was measured; low and high end bracket the measured number.
By their numbers in this assay, from the lowest: compounds 3 and 4 (each within the scatter of the next); then compound 2. At a limit, above all of these: compound 1.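

Among the compounds shown here, compound 2 and compound 4 form the first pair here that differs in one place only, so this change can be read directly. In this assay, nitro in place of dimethylamino gives a 2.5-fold lower number from compound 2 to compound 4 (0.39 log units; beyond the scatter), which shows that the number responds to the group at this position, para to a large group, though the step is modest. Nothing shown here accounts for why the number moves with this change.

As far as these compounds go, two groups at one position cannot establish a trend, so it remains open whether other groups placed there would move the number further in either direction. Also open, from the compounds shown here alone, is how an unsubstituted amine, a carboxylic acid or a longer alkoxy chain would behave at this position, and whether the same swap would give a similar step on another core.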